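Chloro to nitro: a sideways step expected

The compounds below may be only part of what the source reports. "The series", "measured", "known", "first", "only" and "open" are said of these compounds alone.

Going by the values given here, compound 2 `O=C(CSc1nc(Nc2ccccc2)c2ccccc2n1)Nc1cccc(Cl)c1` gives 16500 nM in a functional assay on MDA-MB-231 cells (Homo sapiens) for inhibition, read by MTT assay, with a stated time of 72 h (a lower number here means a stronger inhibitor, a higher number a weaker inhibitor), the only number in this set. Compound 1 `O=C(CSc1nc(Nc2ccccc2)c2ccccc2n1)Nc1ccccc1F` reaches only a limit of this assay, > 50000 nM. Among the compounds with values here, the step of an at least 3.0-fold lower number from compound 1 to compound 2 (0.48 log units; beyond the scatter) is the sole measured comparison, and its size is bounded by the limit of > 50000 nM in this assay, at which 1 of the 2 values shown sits. Compound 3 `O=C(CSc1nc(Nc2ccccc2)c2ccccc2n1)Nc1cccc([N+](=O)[O-])c1` differs from compound 2 by nitro in place of chloro on an aromatic carbon. Within the data shown here, that measured step differs from this one in both the group and where it sits, so it bears on the nitro exchange only loosely; no measured pair isolates this change. Compound 3 is therefore expected to give 20000 nM (range 6000 nM to 60000 nM), a step of a 1.2-fold higher number from compound 2 to compound 3 (0.08 log units; within the scatter) within the scatter.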

Compound 3, half-maximal inhibitory concentration: 33000 nM
Compound 3: middle estimate off by 1.7-fold (0.22 log units), on the low side; low and high end bracket the measured number.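

In this assay, the step of a 2.0-fold higher number from compound 2 to compound 3 (0.30 log units; within the scatter) shows that chloro and nitro cannot be separated on this aromatic carbon, so the 3-substituted anilide keeps its level with either group. The second step, an at least 1.5-fold lower number from compound 1 to compound 3 (0.18 log units; that floor lies within the scatter), does not clearly set 3-nitrophenyl apart from 2-fluorophenyl, although 3-chlorophenyl was set apart. Compound 1 stands at a limit, so this step gives only a floor: the limit of > 50000 nM in this assay, at which 1 of the 3 values shown sits.

Going by these compounds, whether an amine or a carboxylic acid on this carbon would move the number beyond the scatter remains open. So does whether chloro and nitro would stay level on another carbon of this ring.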